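Swapping a ring sulfur for oxygen in two related cores

The source may report more compounds than this note shows. Statements on the series, on what has been measured and on what is new or still open speak of the compounds shown alone.

Four compounds are compared in a functional assay, tested at 50 ug/mL; a lower number here means a weaker effect, a higher number a stronger effect of the compound at the concentration tested. Compound 1, `Cc1ccc(C2CNN=C2S(=O)(=O)CC2=NCCS2)cc1`, gives 39.8% in this assay. Compound 3, `Cc1ccc(C2CNN=C2S(=O)(=O)CC2=NCCO2)cc1`, gives 41.3%. The change from compound 1 to compound 3 is a group of 5 heavy atoms (3 carbon, 1 nitrogen, 1 oxygen; one five-membered non-aromatic ring with 2 hetero atoms) in place of a group of 5 heavy atoms (3 carbon, 1 nitrogen, 1 sulfur; one five-membered non-aromatic ring with 2 hetero atoms), on a saturated chain carbon bound to a sulfonyl sulfur, and it made a step of a number 1.5 percentage points higher from compound 1 to compound 3 (within the scatter).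

Compound 2, `Cc1ccc(-c2c[nH]nc2S(=O)(=O)CC2=NCCS2)cc1`, is reported in this assay as "not active" (no number reported), so no single number stands for it. How the core of compound 2 differs from the core of compound 1 is not broken down here.

Compound 4, `Cc1ccc(-c2c[nH]nc2S(=O)(=O)CC2=NCCO2)cc1`, has not been measured. It differs from compound 2 by a group of 5 heavy atoms (3 carbon, 1 nitrogen, 1 oxygen; one five-membered non-aromatic ring with 2 hetero atoms) in place of a group of 5 heavy atoms (3 carbon, 1 nitrogen, 1 sulfur; one five-membered non-aromatic ring with 2 hetero atoms), on a saturated chain carbon bound to a sulfonyl sulfur, the same change that was made from compound 1 to compound 3. Because that earlier step a number 1.5 percentage points higher from compound 1 to compound 3 (within the scatter) stayed within the scatter, the same change is expected to move compound 4 little from where compound 2 stands. Compound 4 is therefore expected to give about 10% in this assay, with an estimated range from 0% to 30%, and a fair chance that again only inactivity is reported.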

Compound 4, a percentage reported as activity, at one concentration (the size of the read-out at that concentration, not a potency): 60.7%
Estimate against measurement, compound 4: 50.7 percentage points below; measured number above the stated range.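

Within the data shown here, no step from compound 2 to compound 4 can be read: in this assay compound 2 is reported as "not active" (no number reported) and compound 4 gives 60.7%. No data shown here bear on the reason for this result. The compounds shown leave open whether swapping the ring sulfur for oxygen has a different effect on the core of compound 2 than on the core of compound 1.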